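The source may report more compounds than this note shows. Statements on the series, on what has been measured and on what is new or still open speak of the compounds shown alone.

Four compounds are considered here, all tested, or to be tested, in a functional assay on the whole organism (strain albino) for inhibition, with Rattus norvegicus as the target, read by paw edema, with stated times of 30 min and 3 h, at a dose of 0.28 mmol/kg by the oral route; a lower number here means less inhibition, a higher number more inhibition at the dose given (going by the name of the read-out). Compound 1 `C=CCn1c(SCC(=O)Nc2ccc(C(C)=O)cc2)nnc1-c1ccccc1` and compound 2 `C=CCn1c(SCC(=O)Nc2ccc(/C(C)=N/O)cc2)nnc1-c1ccccc1` share one core and differ in a single group on the outer aromatic ring. Compound 3 `CCn1c(SCC(=O)Nc2ccc(/C(C)=N/O)cc2)nnc1-c1ccc(OC)c(OC)c1` and compound 4 `CCn1c(SCC(=O)Nc2ccc(C(C)=O)cc2)nnc1-c1ccc(OC)c(OC)c1` share a second core; the difference between the two cores is not broken down here.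

In this assay compound 1 gives 54%. Compound 2 gives 73%, and compound 3 gives 66%; the number for compound 3 lies within the usual scatter of that for compound 2, while the gap to compound 1 lies beyond the scatter. The structural change from compound 2 to compound 1 is a group of 3 heavy atoms (2 carbon, 1 oxygen; no ring) in place of a group of 4 heavy atoms (2 carbon, 1 nitrogen, 1 oxygen; no ring), on an aromatic carbon and in this assay it made a number 19 percentage points lower from compound 2 to compound 1 (beyond the scatter).

The change from compound 3 to compound 4 is the same change: a group of 3 heavy atoms (2 carbon, 1 oxygen; no ring) in place of a group of 4 heavy atoms (2 carbon, 1 nitrogen, 1 oxygen; no ring), on an aromatic carbon The group that leaves, the group that enters and the place are described in the same words in both cases. Compound 4 has not yet been measured in this assay.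

Among the compounds with values here, the step from compound 3 to compound 4 is expected to be a number 19 percentage points lower from compound 3 to compound 4 (beyond the scatter) because the only measured example of this change is a number 19 percentage points lower from compound 2 to compound 1 (beyond the scatter). Compound 4 is accordingly expected to give about 47%, most likely somewhere between 35% and 60%.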

Compound 4, a percentage reported as inhibition, in the whole organism at one dose (the size of the read-out at that dose, not a potency): 62%
Estimate against measurement, compound 4: 15 percentage points below; the whole stated range lies below it.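

In this assay, putting acetyl in place of the group of 4 heavy atoms on the aromatic carbon gives a number 4 percentage points lower from compound 3 to compound 4 (within the scatter), so on this second core the swap produces no change that can be told apart from ordinary variation between repeat measurements. Set beside the earlier pair, the same change did not keep its size from one core to the other: the same change on two cores in this assay, a number 19 percentage points lower (beyond the scatter) from compound 2 to compound 1 and a number 4 percentage points lower (within the scatter) from compound 3 to compound 4, 15 percentage points apart, beyond the scatter of two such steps. This shows that a step measured on one core in this series cannot simply be added to a compound on the other core, but it does not show what causes the mismatch, and two pairs are too few to say how the step would behave on any further core.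

The compounds shown leave open which part of the core matters, as no pair separates the allyl and ethyl chains from the presence or absence of the two methoxy groups on the outer phenyl ring. They also leave open how an amine or a carboxylic acid at the same place, in place of acetyl, would compare on either core.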